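Furan-3-yl for thiophen-2-yl on the shared core

The source may report more compounds than this note shows. Statements on the series, on what has been measured and on what is new or still open speak of the compounds shown alone.

Compound 3 `CNc1ncnc2c1c(-c1cccs1)cn2[C@@H]1O[C@H](CO)[C@@H](O)[C@H]1O` is read in a functional assay on A549 cells (Homo sapiens), read by MTT assay, with a stated time of 72 h (on this read-out lower numbers stand for stronger inhibition and higher numbers for weaker inhibition), only as a limit: compound 3 gives > 20000 nM. Compound 1 `CN(C)c1ncnc2c1c(-c1ccoc1)cn2[C@@H]1O[C@H](CO)[C@@H](O)[C@H]1O` also gives only a limit in this assay, > 20000 nM. Compound 2 `C#Cc1cn([C@@H]2O[C@H](CO)[C@@H](O)[C@H]2O)c2ncnc(NC)c12` likewise gives only a limit, > 20000 nM. Within the data shown here, the sole measured step, a step that the two limits leave unreadable from compound 2 to compound 3, is therefore unreadable, and the limit of > 20000 nM in this assay, at which 3 of the 3 values shown sit, shows that none of the three values falls below that limit. The change to compound 4 `CNc1ncnc2c1c(-c1ccoc1)cn2[C@@H]1O[C@H](CO)[C@@H](O)[C@H]1O` is furan-3-yl in place of thiophen-2-yl on an aromatic carbon. Among the measured compounds shown here, no measured step bears on this change directly, and compound 1, which also bears furan-3-yl, stands at the limit. Compound 4 is therefore expected to show a step that the limit leaves unreadable from compound 3 to compound 4 and is estimated at 30000 nM, within 10000 nM to 100000 nM, most likely again reported only as a limit.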

Compound 4, half-maximal inhibitory concentration: > 20000 nM
Compound 4: a limit, no number; the forecaster's own chance of this, stated with the estimate: 85%; the middle value does not contradict the limit.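

In this assay compound 4 gives > 20000 nM, which is a limit. No step from compound 1, compound 2 or compound 3 to compound 4 can be read: the limit of > 20000 nM in this assay, at which 4 of the 4 values shown sit.

The compounds shown leave open whether any group on the shared core gives a numerical value in this assay.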